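A few compounds are considered here, and "the series" means these few. Any claim that something is new, unique, unknown or untested is made for them only; others in the source may bear on it.

Values in an ADME assay on MCF-10A cells (Homo sapiens) for cytotoxicity, read by CCK-8 assay and cell counting, with a stated time of 72 h; on this read-out higher numbers stand for weaker inhibition and lower numbers for stronger inhibition:
compound 1 `COc1ccc(-c2cc3ccccc3c(-c3ccc(O)cc3)n2)cc1`: > 50000 nM
compound 2 `COc1ccc(-c2cc3ccccc3c(-c3ccc(OC)cc3)n2)cc1`: > 50000 nM
compound 3 `COc1cc(OC)cc(-c2cc3ccccc3c(-c3cccc(O)c3)n2)c1`: 6770 nM

The value of compound 1 is a limit of this assay, not a number. The same holds for compound 2. Going by the values given here, of the three values shown, only that of compound 3 is a number. Compound 4 `COc1cc(OC)cc(-c2cc3ccccc3c(-c3cccc(OC)c3)n2)c1` remains to be measured in this assay.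

Compound 2 differs from compound 1 by methyl in place of hydrogen on an oxygen on an aromatic ring. Compound 4 differs from compound 3 by methyl in place of hydrogen on an oxygen on an aromatic ring. The two places read the same word for word, so this is the same change, made twice among the compounds shown. The difference between the core of compound 1 and that of compound 3 is not broken down here.

The step that the two limits leave unreadable from compound 1 to compound 2 has a size the two limits do not let one read, because both sit at the limit of > 50000 nM in this assay, at which 2 of the 3 values shown sit. Among the compounds with values here, the one measured example of the change therefore gives no size to carry over to compound 4. For compound 4 the expected step is a 2.2-fold higher number from compound 3 to compound 4 (0.35 log units; beyond the scatter), resting only on compound 3 and its value 6770 nM as the single numerical starting point. There is a real chance that this assay again reports only a limit for compound 4 rather than a number. Compound 4 is accordingly estimated at 15000 nM, with a range from 5000 nM to 50000 nM.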

Compound 4, half-maximal inhibitory concentration: > 50000 nM
Compound 4 ended at the assay's limit (the forecaster's own chance of this, stated with the estimate: 35%); middle value at least 3.3-fold (0.52 log units) away from the limit.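

In this assay, going by these compounds, methyl in place of hydrogen on an oxygen on an aromatic ring gives an at least 7.3-fold higher number from compound 3 to compound 4 (0.86 log units; beyond the scatter), so on the core of compound 3 the change from 3-hydroxyphenyl to 3-methoxyphenyl goes towards weaker inhibition, and the full size of the step stays unknown. On the core of compound 1 the same change cannot be read, so this series holds one example with a lower bound on its size and one with no size, and agreement between the two cores in direction or size is not shown: the limit of > 50000 nM in this assay, at which 3 of the 4 values shown sit. The step on the core of compound 3 therefore stands for that core alone and gives no measure that can be carried to another core.

Going by these compounds alone, compound 3, at 6770 nM, holds the only number in this assay, which leaves open whether a measurable value depends on the hydroxy group or on the core that carries it. Also open, on these data alone, is how an amine, a carboxylic acid or an ethoxy group in place of the hydroxy group of compound 3 would read in this assay.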